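Swapping the amine arms on a shared core

The source may hold more compounds than are shown below. What is called first, only, known or untested is meant among the compounds shown, and "the series" means these compounds.

compound 1 `CCN(Cc1c(C(F)(F)F)nc2n(-c3c(C)cc(C)cc3C)c(Cl)cn12)CC1CC1` gives 9 nM
compound 2 `CCCN(CCC(F)(F)F)Cc1c(C(F)(F)F)nc2n(-c3c(C)cc(C)cc3C)c(Cl)cn12` gives 12 nM
compound 3 `CCCN(Cc1c(C(F)(F)F)nc2n(-c3c(C)cc(C)cc3C)c(Cl)cn12)CC1CCC1` gives 5.3 nM

All three compounds share one core and differ only in the amine that sits on a saturated chain carbon bound to an aromatic carbon. In an assay on cells for displacement of a labelled ligand from corticotropin-releasing factor receptor 1 (Homo sapiens), with a stated time of 100 min (a lower number here means a stronger inhibitor, a higher number a weaker inhibitor), compound 3 shows the lowest of the three numbers. The step of a 1.7-fold lower number from compound 1 to compound 3 (0.23 log units; within the scatter) stays within the usual scatter, so compound 3 and compound 1 cannot be told apart, whereas the step of a 2.3-fold lower number from compound 2 to compound 3 (0.35 log units; beyond the scatter) is a modest but real difference.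

Compound 4 `Cc1cc(C)c(-n2c(Cl)cn3c(CN(C)Cc4ccccc4)c(C(F)(F)F)nc23)c(C)c1` keeps the same core and changes only that amine: benzyl(methyl)amino in place of (cyclobutylmethyl)(propyl)amino on a saturated chain carbon bound to an aromatic carbon. The measured steps that bear on this are the three exchanges of amine arms already seen, a 1.3-fold higher number from compound 1 to compound 2 (0.12 log units; within the scatter), a 1.7-fold lower number from compound 1 to compound 3 (0.23 log units; within the scatter) and a 2.3-fold lower number from compound 2 to compound 3 (0.35 log units; beyond the scatter); all of them are small, and only one reaches beyond the scatter. Moving from two saturated arms to an aromatic arm with a methyl is a larger departure than any of those, so the uncertainty is wider, but the data give no sign of a big swing in either direction.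

Compound 4 is therefore expected to give about 12 nM in this assay, with a range from 4 nM to 45 nM. The expected step of a 2.3-fold higher number from compound 3 to compound 4 (0.35 log units; beyond the scatter) would most likely stay close to the scatter, with a slight lean toward a higher number.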

Compound 4, inhibition constant: 160 nM
Compound 4: middle estimate off by 13-fold (1.12 log units), on the low side; the whole stated range lies below it.
By their numbers in this assay, from the lowest: compounds 3, 1 and 2 (each within the scatter of the next, the first and the last beyond it); then compound 4.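

In this assay the amine on this saturated chain carbon matters far more than the first three compounds suggested, with a 30-fold higher number from compound 3 to compound 4 (1.48 log units; beyond the scatter) and a 13-fold higher number from compound 2 to compound 4 (1.12 log units; beyond the scatter) and an 18-fold higher number from compound 1 to compound 4 (1.25 log units; beyond the scatter) all counted as large steps toward a weaker inhibitor. The exchanges among the three amines with two saturated arms had stayed small, so their near-equal numbers do not extend to every amine at this position. Leaving and entering groups in the step from compound 3 have the same count of heavy atoms and hydrogen-bond acceptors, so those counts do not separate the two groups, and nothing measured here explains the drop.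

Compound 4 brings in a benzyl arm and a methyl arm together, so the shared data cannot say which of the two carries the loss. Benzyl(propyl)amino would test the benzyl arm with a longer saturated arm retained, while (cyclobutylmethyl)(methyl)amino would test the methyl arm with the saturated ring retained.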